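From 4-chlorophenyl to 4-nitrophenyl: what to expect

The source may hold more compounds than are shown below. What is called first, only, known or untested is meant among the compounds shown, and "the series" means these compounds.

Compound 1 `COc1ccccc1C(=O)NCc1ccc(CNS(=O)(=O)c2ccccc2F)cc1` gives 1 nM in an assay on MDA-MB-231 cells for displacement of a labelled ligand from C-X-C chemokine receptor type 4 (Homo sapiens), read by fluorescence and microscopy, with stated times of 10 min and 30 min; a higher number here means that more compound is needed for the effect, a lower number that less compound is needed.
Compound 2 `COc1ccccc1C(=O)NCc1ccc(CNS(=O)(=O)c2cccc(F)c2)cc1` gives 1000 nM in this assay.
Compound 3 `COc1ccccc1C(=O)NCc1ccc(CNS(=O)(=O)c2ccc(Cl)cc2)cc1` gives 1000 nM in this assay.

Compound 3 stands level with compound 2, the two together giving the highest numbers of the three, while compound 1 sits far away from both: a 1000-fold higher number from compound 1 to compound 3 (3.00 log units; beyond the scatter), and likewise a 1000-fold higher number from compound 1 to compound 2 (3.00 log units; beyond the scatter). Between the two high numbers there is no change at the digits printed from compound 2 to compound 3 (within the scatter).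

Compound 4 `COc1ccccc1C(=O)NCc1ccc(CNS(=O)(=O)c2ccc([N+](=O)[O-])cc2)cc1` has not yet been measured. It differs from compound 3 in one place: nitro in place of chloro on an aromatic carbon.

For the measured compounds named here, no measured compound carries a nitro group, so no step speaks to this group directly. Two things do bear on it. First, the large steps from compound 1 show that the number climbs steeply once the 2-fluorophenyl is replaced, and compound 4, like compound 3, lacks that group. Second, no change at the digits printed from compound 2 to compound 3 (within the scatter) shows that two different groups on the phenyl away from that position gave the same number. Compound 4 is therefore expected to stay in the same high region, with no change at the digits printed from compound 3 to compound 4 (within the scatter) estimated as no change beyond the scatter. For compound 4 the expected value in this assay is 1000 nM, within a range from 300 nM to 3000 nM.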

Compound 4, effective concentration (reported as EC, without a stated level of effect): 100 nM
Compound 4: the middle estimate sits 10-fold (1.00 log units) above what was measured; measured number below the stated range.
By their numbers in this assay, from the lowest: compound 1; then compound 4; then compounds 2 and 3 (each within the scatter of the next).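

Changing only the group on this aromatic carbon gives a 10-fold lower number from compound 3 to compound 4 (1.00 log units; beyond the scatter), so the group here can move the number even without the 2-fluorophenyl. The match between compounds 2 and 3 had not shown this, and the measurement a 10-fold lower number from compound 2 to compound 4 (1.00 log units; beyond the scatter) confirms that their shared high level is not a fixed value for every compound lacking the 2-fluorophenyl; even so, the 4-nitrophenyl leaves a clear gap to the 2-fluorophenyl, with a 100-fold higher number from compound 1 to compound 4 (2.00 log units; beyond the scatter) in the same assay. Nothing available here explains why nitro and chloro give different numbers.

A single chloro-to-nitro swap cannot show whether other groups on this aromatic carbon, such as an amine, a carboxylic acid or a methoxy group, would give a number nearer that of compound 4 or that of compound 3. Going by these compounds, it also remains open what number would come from a phenyl ring carrying both the nitro group and the fluorine, and whether the two changes would add together or not.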